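The source may report more compounds than this note shows. Statements on the series, on what has been measured and on what is new or still open speak of the compounds shown alone.

Three compounds were tested in a functional assay on COLO 205 cells (Homo sapiens) for inhibition, read by sulforhodamine B assay, with a stated time of 48 h, tested at 50 uM; on this read-out lower numbers stand for less inhibition of growth and higher numbers for more inhibition of growth at the one concentration tested. Compound 1 `O=C1C(=O)N(CCCCn2cc(COc3cc(=O)oc4ccccc34)nn2)c2ccc(F)cc21` gives 64% in this assay, and compound 2 `O=C1C(=O)N(CCCn2cc(COc3cc(=O)oc4ccccc34)nn2)c2ccc(F)cc21` gives 69%. These two values lie within the scatter of each other, so no order between them is claimed. Compound 3 `COc1ccc2c(c1)C(=O)C(=O)N2CCCCCn1cc(COc2cc(=O)oc3ccccc23)nn1` gives 19% and stands lowest of the three numbers: compound 1 is its nearest neighbour, at a distance beyond the scatter, and compound 2 its furthest, also beyond the scatter.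

Compound 4 `O=C1C(=O)N(CCCCCn2cc(COc3cc(=O)oc4ccccc34)nn2)c2ccc(Br)cc21` has not yet been measured. It differs from compound 3 in one place: bromo in place of methoxy on an aromatic carbon. Going by the values given here, no measured pair isolates this change, since compound 1 and compound 2 carry a fluoro group on a shorter chain, not a bromo group on the same chain as compound 3. Still, the two fluoro-bearing compounds sit well above compound 3, which suggests that replacing the methoxy of compound 3 may move the number upward. The step expected in this assay is a number 21 percentage points higher from compound 3 to compound 4 (beyond the scatter), upward and beyond the scatter, though with wide uncertainty. The estimate for compound 4 in this assay is 40%, with a range from 15% to 70%.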

Compound 4, percent growth inhibition at one concentration: 39%
The estimate for compound 4 lay 1 percentage points above the measured number; measured number inside the range.
By their numbers in this assay, from the lowest: compound 3; then compound 4; then compounds 1 and 2 (each within the scatter of the next).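

In this assay, going by these compounds alone, the exchange of methoxy for bromo gives a number 20 percentage points higher from compound 3 to compound 4 (beyond the scatter) and so provides the first comparison in this set in which a single place changes while the rest of the structure stays the same. It shows that the read-out is not indifferent to what sits on this aromatic carbon, meta to a fused ring and para to a fused ring: a two-atom group with one hydrogen-bond acceptor leaves, a single bromine atom with none enters, and the number moves beyond the usual scatter. Nothing at hand bears on why the number moves with this exchange.

As far as these compounds go, whether the gain belongs to bromo in particular, or would also appear with a hydrogen, a chloro group or an amine at this place, remains open. From the compounds shown here alone, whether the same step holds on a shorter chain is also open, since compound 1 and compound 2 differ from compound 4 in both the halogen and the chain, and no single-place step can be read between them.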